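The source may hold more compounds than are shown below. What is called first, only, known or untested is meant among the compounds shown, and "the series" means these compounds.

Working notes on the series in a functional assay on the whole organism (spleen, spleen) with Rattus norvegicus as the target; on this read-out lower numbers stand for an effect already at smaller amounts and higher numbers for an effect only at larger amounts of compound.

Three compounds share the core seen in compound 1 `CCCCCCCCc1ccc(CCC(N)(CO)C(=O)O)cc1`. In this assay compound 1 gives > 10 mg/kg, which is a limit of the assay and not a number. Compound 2 `CCCCCCCCc1ccc(CCC(N)CO)cc1` has hydrogen in place of carboxy on a saturated chain carbon bound to an amine nitrogen and two saturated chain carbons. In this assay compound 2 also gives > 10 mg/kg, again a limit and not a number. The step that the two limits leave unreadable from compound 1 to compound 2 is therefore unreadable in size and direction, since the limit of > 10 mg/kg in this assay, at which 2 of the 3 values shown sit, bounds both ends of it. Going by the values given here, compound 3 `CCCCCCCOc1ccc(CCC(N)(CO)CCC)cc1` is the only member with a number: in this assay compound 3 gives 3.1 mg/kg.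

Compound 4 `CCCCCCCCc1ccc(CCC(N)(CO)CCO)cc1` is the next entry to be measured. Relative to compound 2 the change is 2-hydroxyethyl in place of hydrogen on a saturated chain carbon bound to an amine nitrogen and two saturated chain carbons. Among the compounds with values here, no measured step in the set bears directly on this change; the one measured step is unreadable, so no expected size or direction can be taken from it. Compound 3 shows that a member of this core carrying a further carbon chain on that carbon does reach a number in this assay, and the estimate for compound 4 leans on that value alone. For compound 4 the expected result is 3 mg/kg, within 1 mg/kg to 10 mg/kg, which would mean an estimated step of an at least 3.3-fold lower number from compound 2 to compound 4 (0.52 log units; beyond the scatter).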

Compound 4, dose for 50% inhibition: 0.009 mg/kg
For compound 4 the middle estimate is 330-fold (2.52 log units) above the measured one; measured number outside the range, below it.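

In this assay, going by these compounds alone, the saturated chain carbon bound to an amine nitrogen and two saturated chain carbons proves highly sensitive to substitution, which the earlier compounds could not show, since the only step available there was unreadable. With 2-hydroxyethyl in place of hydrogen the series shows an at least 1100-fold lower number from compound 2 to compound 4 (3.04 log units; beyond the scatter), and with 2-hydroxyethyl in place of carboxy on the same carbon it shows an at least 1100-fold lower number from compound 1 to compound 4 (3.04 log units; beyond the scatter). Both steps start from a limit of the assay and not from a number, so each gives only a bound on the size of the change: the limit of > 10 mg/kg in this assay, at which 2 of the 4 values shown sit.

Within the data shown here, the step between the two limits still cannot be read, so hydrogen and carboxy at this carbon cannot be ranked, and compound 3 differs from compound 4 in more than one place, so it gives no step for this change. Among the compounds shown, the effect of the 2-hydroxyethyl group cannot be divided between its chain and its hydroxyl, and an ethyl or 3-hydroxypropyl group on this carbon would be needed to separate the two.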